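This account rests on a few compounds, and the source may have more. Where it says the series, first, only, none or still open, it means among the compounds named here.

Compounds measured so far in a functional assay (aorta) with Rattus norvegicus as the target; a lower number here means a less potent compound, a higher number a more potent compound, by a factor of ten per unit of this negative logarithm:
compound 1, `CC1(C)C=C(n2ccccc2=O)c2cc(O)ccc2O1`, 5.44
compound 2, `CC1(C)C=C(n2ccccc2=O)c2cc(-c3ccncc3)ccc2O1`, 6.68

Going by the values given here, compound 2 stands highest of the two numbers; the only measured step is a number 1.24 log units higher from compound 1 to compound 2 (beyond the scatter). Compound 3, `CC1(C)C=C(n2ccccc2=O)c2cc(C(F)(F)F)ccc2O1`, differs from compound 2 in one place: trifluoromethyl in place of pyridin-4-yl on an aromatic carbon. Among the compounds with values here, that step replaced a hydroxy group, not a pyridin-4-yl group, so no measured step bears directly on this change, and the large gain in that step offers only a loose guide. A downward step is expected, a number 0.58 log units lower from compound 2 to compound 3 (beyond the scatter). Compound 3 is therefore expected to give 6.1, within 5.3 to 6.9.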

Compound 3, logarithm of the reciprocal of the active concentration, log(1/C): 7.61
Compound 3: the middle estimate sits 1.51 log units below what was measured; the measured number lies above the stated range.
By their numbers in this assay, from the lowest: compound 1; then compound 2; then compound 3.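

Trifluoromethyl in place of pyridin-4-yl gives a number 0.93 log units higher from compound 2 to compound 3 (beyond the scatter) in this assay, so among these compounds an aromatic ring on this aromatic carbon is not needed for the highest number. Set against hydroxy, trifluoromethyl gives a number 2.17 log units higher from compound 1 to compound 3 (beyond the scatter) as the widest gap in the set. No evidence is available to account for these gains. 

The compounds shown leave open whether a nitrile, a chlorine or a methyl on this carbon would match trifluoromethyl. They also leave open whether an amine there would stand nearer to hydroxy.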